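Methoxy in place of ring hydrogen on compound 2

The source may report more compounds than this note shows. Statements on the series, on what has been measured and on what is new or still open speak of the compounds shown alone.

Three allenic amines have been measured in an assay on isolated protein for inhibition of Monoamine oxidase (Rattus norvegicus); on this read-out lower numbers stand for stronger inhibition and higher numbers for weaker inhibition. Compound 1 `C=C=CCN(C)Cc1ccccc1` gives 170 nM, compound 2 `C=C=C(CN)Cc1ccccc1` gives 140 nM, and compound 3 `C=C=C(CN)Cc1ccc(C)cc1` gives 360 nM. Compound 2 sits at the low end of these three numbers; compound 1 lies within the scatter of it, while compound 3 lies beyond the scatter, as the step of a 2.6-fold higher number from compound 2 to compound 3 (0.41 log units; beyond the scatter) shows.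

Compound 4 `C=C=C(CN)Cc1ccc(OC)cc1` has not yet been measured. It differs from compound 2 by methoxy in place of hydrogen on an aromatic carbon. For the measured compounds named here, the only measured step that bears on this change is the one from compound 2 to compound 3, where a methyl entered at the same aromatic carbon and brought a 2.6-fold higher number from compound 2 to compound 3 (0.41 log units; beyond the scatter). A methoxy at that carbon is a change of the same kind, so a modest rise in the number is expected again in this assay, though its exact size is uncertain. Compound 4 is therefore estimated at 350 nM, with a range from 150 nM to 800 nM. This estimate implies an expected step of a 2.5-fold higher number from compound 2 to compound 4 (0.40 log units; beyond the scatter).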

Compound 4, half-maximal inhibitory concentration: 580 nM
Compound 4: middle estimate off by 1.7-fold (0.22 log units), on the low side; the measured number falls inside the stated range.
By their numbers in this assay, from the lowest: compounds 2 and 1 (each within the scatter of the next); then compounds 3 and 4 (each within the scatter of the next).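

In this assay, the step (a 4.1-fold higher number from compound 2 to compound 4 (0.62 log units; beyond the scatter)) shows that the rise seen with methyl at this aromatic carbon is not unique to that group: a second, different group placed there also gives a number beyond the scatter of the unsubstituted compound. The step (a 1.6-fold higher number from compound 3 to compound 4 (0.21 log units; within the scatter)) stays within the scatter, so the two groups cannot be told apart at this carbon, and no order between them can be drawn. Both substituted compounds therefore move the same way from compound 2, and none of the compounds shown goes against this. Nothing shown accounts for the rise.

The compounds shown leave open whether a halogen such as fluorine, a hydroxyl or an amine at this carbon would behave the same way. They also do not tell whether methoxy elsewhere on the ring would bring a similar rise.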